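A Fluoro Swap on the Shorter-Lived Compound

This account rests on a few compounds, and the source may have more. Where it says the series, first, only, none or still open, it means among the compounds named here.

In an ADME assay on microsomes from liver (Rattus norvegicus) for metabolic stability (on this read-out lower numbers stand for a shorter-lived compound and higher numbers for a longer-lived compound), compound 1 (`CC#C[C@@H](Cc1nnn[nH]1)c1ccc(OCc2ccc3scc(-c4ccc(OCCCS(C)(=O)=O)cc4C)c3c2)cc1`) gives 1.48 h and compound 2 (`CC#C[C@@H](Cc1nnn[nH]1)c1ccc(OCc2ccc3sc(C)c(-c4ccc(OCCOC)cc4C)c3c2)cc1`) gives 0.117 h as the lower of the two numbers. The gap between them lies beyond the usual scatter. The two compounds differ in more than one place, so this gap cannot be tied to any single change.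

Compound 3 (`CC#C[C@@H](Cc1nnn[nH]1)c1ccc(OCc2ccc3sc(F)c(-c4ccc(OCCOC)cc4C)c3c2)cc1`) departs from compound 2 in one place only: fluoro in place of methyl on an aromatic carbon in a swap of fluoro in place of methyl on an aromatic carbon. This carbon belongs to a five-membered aromatic ring with 1 sulfur and lies next to the ring sulfur.

Among the measured compounds shown here, no measured pair shows this swap on its own, so the expectation rests on thin ground. With compound 2 at 0.117 h and compound 1 at 1.48 h the measured span leaves more room upward than downward, and a modest rise is expected. The estimated change is a 2.1-fold higher number from compound 2 to compound 3 (0.33 log units; beyond the scatter) and would sit near the edge of the scatter. Compound 3 is estimated at 0.25 h (expected range 0.1 h to 0.7 h).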

Compound 3, half-life: 0.35 h
Compound 3: middle estimate off by 1.4-fold (0.15 log units), on the low side; measured number inside the range.
By their numbers in this assay, from the lowest: compound 2; then compound 3; then compound 1.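

In this assay, the carbon next to the ring sulfur proves able to shift the half-life on its own: fluoro in place of methyl at this carbon gives a 3.0-fold higher number from compound 2 to compound 3 (0.48 log units; beyond the scatter) with the rest of the structure unchanged. Among the compounds shown here, this is the first step here that ties a change beyond the scatter to one place, which the gap between the first two compounds, differing in more than one place, could not do. It also shows that a single heavy atom exchanged at this carbon, with no change in the counts of hydrogen-bond donors and acceptors or in net charge, is enough for a modest step. Nothing at hand explains the rise.

This single pair leaves open whether the step belongs to fluoro in particular or would also appear with chloro, a nitrile or trifluoromethyl on the same carbon. It also leaves open whether the same swap gives a similar step when the neighbouring 4-(2-methoxyethoxy)-2-methylphenyl group carries a longer chain or an amine in place of its 2-methoxyethoxy chain.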